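Phenoxy in Place of Hydrogen on the Aromatic Ring

A few compounds are considered here, and "the series" means these few. Any claim that something is new, unique, unknown or untested is made for them only; others in the source may bear on it.

Compound 1 `C=C/C=C\[C@H](C)[C@H](OC(N)=O)[C@@H](C)[C@H](O)[C@@H](C)C/C(C)=C\[C@H](C)[C@@H](O)[C@@H](C)/C=C\CCc1ccccc1` gives 350 nM in a functional assay on SK-OV-3 cells (Homo sapiens) for cytotoxicity; a higher number here means a weaker inhibitor, a lower number a stronger inhibitor.
Compound 2 `C=C/C=C\[C@H](C)[C@H](OC(N)=O)[C@@H](C)[C@H](O)[C@@H](C)C/C(C)=C\[C@H](C)[C@@H](O)[C@@H](C)/C=C\CCc1cccc(O)c1` gives 40 nM.
Compound 3 `C=C/C=C\[C@H](C)[C@H](OC(N)=O)[C@@H](C)[C@H](O)[C@@H](C)C/C(C)=C\[C@H](C)[C@@H](O)[C@@H](C)/C=C\CCc1cccc(Cl)c1` gives 380 nM.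

On these numbers compound 1 stands second highest of the three. Compound 4 `C=C/C=C\[C@H](C)[C@H](OC(N)=O)[C@@H](C)[C@H](O)[C@@H](C)C/C(C)=C\[C@H](C)[C@@H](O)[C@@H](C)/C=C\CCc1ccc(Oc2ccccc2)cc1` differs from compound 1 by phenoxy in place of hydrogen on an aromatic carbon. Two measured steps from compound 1 bear on this change. Putting chloro on the aromatic ring gave a 1.1-fold higher number from compound 1 to compound 3 (0.04 log units; within the scatter), a move within the scatter. Putting hydroxy there gave an 8.8-fold lower number from compound 1 to compound 2 (0.94 log units; beyond the scatter), a clear move to a lower number. A phenoxy group carries no hydroxy; the chloro step is the closer guide. In this assay the expected step is therefore within the scatter, perhaps drifting slightly toward a higher number, a 1.3-fold higher number from compound 1 to compound 4 (0.11 log units; within the scatter). Compound 4 is thus estimated at 450 nM, within a range from 150 nM to 1400 nM.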

Compound 4, half-maximal inhibitory concentration: 10000 nM
Compound 4: middle estimate off by 22-fold (1.35 log units), on the low side; measured number above the stated range.
By their numbers in this assay, from the lowest: compound 2; then compounds 1 and 3 (each within the scatter of the next); then compound 4.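

In this assay, among these compounds, phenoxy, para to a large group, gave a 29-fold higher number from compound 1 to compound 4 (1.46 log units; beyond the scatter) and so produced the first large upward step in this set. The chloro and hydroxy steps gave no sign that a change on this ring could cost so much activity. Nothing measured here explains the loss.

On these data alone, whether the loss follows from the added benzene ring or from the ether oxygen remains open. A methoxy or a benzyl group at this same place would help to tell the two apart.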